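Benzyl ring substitution and cytotoxicity across the series

This account rests on a few compounds, and the source may have more. Where it says the series, first, only, none or still open, it means among the compounds named here.

Values in an ADME assay on MT4 cells (Homo sapiens) for cytotoxicity, read by MTT assay, with a stated time of 5 days; a higher number here means that more compound is tolerated, a lower number that less compound is tolerated:

Compound 1 `Cc1cccc(Cn2cc(CNC(=O)c3cnc(Nc4ccc(C#N)cc4)cc3Oc3c(C)cc(C)cc3C)nn2)c1`: 114000 nM
Compound 2 `Cc1cc(C)c(Oc2cc(Nc3ccc(C#N)cc3)ncc2C(=O)NCc2cn(Cc3ccccc3C#N)nn2)c(C)c1`: > 219000 nM, a limit of the assay rather than a number
Compound 3 `Cc1cc(C)c(Oc2cc(Nc3ccc(C#N)cc3)ncc2C(=O)NCc2cn(Cc3ccc(F)cc3)nn2)c(C)c1`: >= 153000 nM, likewise a limit of the assay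

Compound 1 is the only one of the three with a plain number; the other two values are limits. The step of an at least 1.9-fold higher number from compound 1 to compound 2 (0.28 log units; that floor lies within the scatter) and the step of an at least 1.3-fold higher number from compound 1 to compound 3 (0.12 log units; that floor lies within the scatter) both run toward more tolerated compound, yet each rests on a limit, the limit of > 219000 nM in this assay, at which 1 of the 3 values shown sits, and (the limit of >= 153000 nM in this assay, at which 1 of the 3 values shown sits), and each floor lies within the scatter, so neither shows a real change. The step that the two limits leave unreadable from compound 2 to compound 3 cannot be read at all.

Compound 4 `Cc1cc(C)c(Oc2cc(Nc3ccc(C#N)cc3)ncc2C(=O)NCc2cn(Cc3cccc(C#N)c3)nn2)c(C)c1` differs from compound 1 by cyano in place of methyl on an aromatic carbon. Among the measured compounds shown here, the closest measured step is the one to compound 2, which also brings a cyano onto the benzyl ring, and it gave only a floor inside the scatter. For compound 4 no step beyond the scatter is therefore expected in this assay, the expected step of a 1.5-fold higher number from compound 1 to compound 4 (0.17 log units; within the scatter) leaning at most slightly toward a higher number. A limit rather than a number is about as likely as not for compound 4. The estimate for compound 4 is 170000 nM, within 90000 nM to 350000 nM.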

Compound 4, half-maximal cytotoxic concentration: >= 129000 nM
Compound 4 was reported as a limit; the forecaster's own chance of this, stated with the estimate: 55%; the middle value is on the limit's open side.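

In this assay compound 4 is also reported as a limit and not a number, so a nitrile on the benzyl ring, here meta to a large group, yields no plain value at this position: the limit of >= 129000 nM in this assay, at which 1 of the 4 values shown sits. Cyano in place of methyl gives an at least 1.1-fold higher number from compound 1 to compound 4 (0.05 log units; that floor lies within the scatter), which shows no real change on going from 3-methylbenzyl to 3-cyanobenzyl, and the true size of the step remains unknown. With compound 2 and compound 4, a cyano group has now been tried at two places on the benzyl ring, and neither floor leaves the scatter, so nothing here ties the tolerated concentration to where the cyano group sits.

Going by these compounds, the steps among compound 2, compound 3 and compound 4 cannot be read, and the order of these three remains open, as does how far each true value lies from its limit. Also open, on these data alone, is whether an amine or a carboxylic acid on the benzyl ring would give a plain number that differs from compound 1 by more than the scatter.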